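Ethylamino to propanoylamino: the expected step

The compounds below may be only part of what the source reports. "The series", "measured", "known", "first", "only" and "open" are said of these compounds alone.

In a functional assay on HCT-116 cells (Homo sapiens) for inhibition (on this read-out lower numbers stand for stronger inhibition and higher numbers for weaker inhibition), compound 2 `CCNCc1cc(-c2c(C(=O)NCC)noc2-c2cc(C(C)C)c(O)cc2O)on1` gives the lowest of the three measured numbers, 45 nM. Compound 1 `CCNC(=O)c1noc(-c2cc(C(C)C)c(O)cc2O)c1-c1cc(CNC)no1` gives 164 nM and compound 3 `CCNC(=O)c1noc(-c2cc(C(C)C)c(O)cc2O)c1-c1cc(CNC(C)=O)no1` gives 167 nM. Compound 4 `CCNC(=O)c1noc(-c2cc(C(C)C)c(O)cc2O)c1-c1cc(CNC(=O)CC)no1` carries propanoyl in place of ethyl on an amine nitrogen. The closest measured change is acetyl in place of ethyl on an amine nitrogen, a 3.7-fold higher number from compound 2 to compound 3 (0.57 log units; beyond the scatter). Acetyl in place of methyl on an amine nitrogen gave a 1.0-fold higher number from compound 1 to compound 3 (0.01 log units; within the scatter), and methyl in place of hydrogen on the chain gave a 3.6-fold lower number from compound 1 to compound 2 (0.56 log units; beyond the scatter). The step expected in this assay is therefore a 3.8-fold higher number from compound 2 to compound 4 (0.58 log units; beyond the scatter), toward a higher number. For compound 4 the estimate is 170 nM, with an expected range of 80 nM to 350 nM.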

Compound 4, half-maximal inhibitory concentration: 78 nM
Estimate against measurement, compound 4: 2.2-fold (0.34 log units) above, outside the stated range (below it).
By their numbers in this assay, from the lowest: compounds 2 and 4 (each within the scatter of the next); then compounds 1 and 3 (each within the scatter of the next).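

In this assay, an acyl group on this amine nitrogen need not cost activity, as propanoyl in place of ethyl gives a 1.7-fold higher number from compound 2 to compound 4 (0.24 log units; within the scatter). Propanoyl also separates from the shorter or smaller groups at this nitrogen, with a 2.1-fold lower number from compound 1 to compound 4 (0.32 log units; beyond the scatter) and a 2.1-fold lower number from compound 3 to compound 4 (0.33 log units; beyond the scatter). Methyl in place of hydrogen at the end of the chain thus lowers the number on both the amine and the acyl side chains: the same change on two cores in this assay, a 3.6-fold lower number (0.56 log units; beyond the scatter) from compound 1 to compound 2 and a 2.1-fold lower number (0.33 log units; beyond the scatter) from compound 3 to compound 4, 1.7-fold (0.23 log units) apart, within the scatter of two such steps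

On these data alone, whether the lowering continues with butanoyl or a longer acyl chain remains open. So does the outcome with a branched isobutyryl group or a terminal carboxylic acid on this chain.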